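The source may hold more compounds than are shown below. What is called first, only, known or untested is meant among the compounds shown, and "the series" means these compounds.

Series notes. In an ADME assay for permeability, using PAMPA, with a stated time of 30 min, at pH 7.4 (a higher number here means that the compound crosses the layer faster, a lower number that the compound crosses the layer more slowly), compound 2 `COc1ccc(F)cc1CNCCCNc1ccnc2cc(-c3ccc(C(F)(F)F)cc3)ccc12` gives 237 10^-6 cm/s and compound 3 `COc1cccc(CNCCCNc2ccnc3cc(-c4ccc(C(F)(F)F)cc4)ccc23)c1O` gives 237 10^-6 cm/s; the two stand level at the digits given, and the difference between them is 2-hydroxy-3-methoxyphenyl in place of 5-fluoro-2-methoxyphenyl on a saturated chain carbon bound to an amine nitrogen, which gives no change at the digits printed from compound 2 to compound 3 (within the scatter). Compound 1 `COc1ccc(F)cc1CNCCCNc1ccnc2cc(Cc3ccccc3)ccc12` carries the change benzyl in place of 4-(trifluoromethyl)phenyl on an aromatic carbon relative to compound 2, and in this assay compound 1 gives 23 10^-6 cm/s, so the step is a 10-fold lower number from compound 2 to compound 1 (1.01 log units; beyond the scatter).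

Compound 4 `COc1cccc(CNCCCNc2ccnc3cc(Cc4ccccc4)ccc23)c1O` has not yet been measured in this assay. It arises from compound 3 by benzyl in place of 4-(trifluoromethyl)phenyl on an aromatic carbon, the same change as that from compound 2 to compound 1, made at the same place, while the cores of compound 3 and compound 4 differ from those of compound 2 and compound 1 by the change already given, (2-hydroxy-3-methoxyphenyl in place of 5-fluoro-2-methoxyphenyl on a saturated chain carbon bound to an amine nitrogen).

Among the compounds with values here, since that core change left the read-out level, the step from compound 3 to compound 4 is expected to resemble the one seen from compound 2 to compound 1, a 10-fold lower number from compound 2 to compound 1 (1.01 log units; beyond the scatter), and is estimated at a 9.5-fold lower number from compound 3 to compound 4 (0.98 log units; beyond the scatter). Compound 4 is therefore expected to give about 25 10^-6 cm/s, with a plausible range from 10 10^-6 cm/s to 60 10^-6 cm/s, pending measurement.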

Compound 4, apparent permeability: 23 10^-6 cm/s
Estimate against measurement, compound 4: 1.1-fold (0.04 log units) above; the range from low to high includes it.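

In this assay, benzyl in place of 4-(trifluoromethyl)phenyl on the aromatic carbon gives a 10-fold lower number from compound 3 to compound 4 (1.01 log units; beyond the scatter), and this step carries from one core to the other without a visible difference: the same change on two cores in this assay, a 10-fold lower number (1.01 log units; beyond the scatter) from compound 2 to compound 1 and a 10-fold lower number (1.01 log units; beyond the scatter) from compound 3 to compound 4, 1.0-fold (0.00 log units) apart, within the scatter of two such steps.
The exchange at the other end of the molecule, 2-hydroxy-3-methoxyphenyl in place of 5-fluoro-2-methoxyphenyl, gives no change at the digits printed from compound 1 to compound 4 (within the scatter), and it also reads the same with either group on the aromatic carbon: the same change on two cores in this assay, no change at the digits printed (within the scatter) from compound 2 to compound 3 and no change at the digits printed (within the scatter) from compound 1 to compound 4, 1.0-fold (0.00 log units) apart, within the scatter of two such steps.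
Within these four compounds the two changes therefore combine without interaction, but this does not show that the step would hold on any other core, and since benzyl replaces the whole group, the result does not separate the part played by the trifluoromethyl from that of the rest of the group.

Still open, as far as these compounds go, is how a plain phenyl or a 4-chlorophenyl would read on that aromatic carbon, and how a longer chain would read in place of the present saturated chain. From the compounds shown here alone, whether the step would survive on a core carrying a carboxylic acid or an amide also remains open.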